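The source may report more compounds than this note shows. Statements on the series, on what has been measured and on what is new or still open speak of the compounds shown alone.

Of the compounds shown here, three sharing one core have been measured in an assay on HEK293 cells for displacement of a labelled ligand from NPC1-like intracellular cholesterol transporter 1 (Homo sapiens); a lower number here means a stronger inhibitor, a higher number a weaker inhibitor. Compound 1 `CC(C)(C)c1ccc(C(=O)N2CCC3(CC2)C(=O)N(CC(=O)N2CCCC(C(N)=O)C2)CN3c2ccccc2)cc1` gives 16900 nM, compound 2 `CC1(C)CC(OC(=O)CN2CN(c3ccccc3)C3(CCN(C(=O)c4ccc(C(C)(C)C)cc4)CC3)C2=O)CC(C)(C)N1` gives 1300 nM, and compound 3 `CC(C)(C)c1ccc(C(=O)N2CCC3(CC2)C(=O)N(CC(=O)NCCCNS(C)(=O)=O)CN3c2ccccc2)cc1` gives 10400 nM. Compound 3 therefore stands second highest of the three numbers: its gap to compound 1 is within the scatter, while the step of an 8.0-fold higher number from compound 2 to compound 3 (0.90 log units; beyond the scatter) is the only one that separates it clearly from another compound.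

The next compound to be considered is compound 4 `CC(C)(C)c1ccc(C(=O)N2CCC3(CC2)C(=O)N(CC(=O)N2CCCCC2CCO)CN3c2ccccc2)cc1`. It differs from compound 3 at a single position: 2-(2-hydroxyethyl)piperidin-1-yl in place of (3-(methanesulfonamido)propyl)amino on a carbonyl carbon.

Within the data shown here, two measured steps touch the same carbonyl carbon. The step of a 1.6-fold lower number from compound 1 to compound 3 (0.21 log units; within the scatter) shows that exchanging a piperidine amide for an open-chain sulfonamide changed little, whereas the step of a 13-fold lower number from compound 1 to compound 2 (1.11 log units; beyond the scatter) shows that the tetramethylpiperidinyl ester lowered the number strongly. Compound 4 returns to a piperidine amide, as in compound 1, and keeps one hydrogen-bond donor, so no step beyond the scatter is expected in this assay, in either direction. Compound 4 is accordingly estimated at 12000 nM, with a range from 4000 nM to 35000 nM. For compound 4 the expected step is a 1.2-fold higher number from compound 3 to compound 4 (0.06 log units; within the scatter).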

Compound 4, half-maximal inhibitory concentration: 6100 nM
Compound 4: the middle estimate sits 2.0-fold (0.29 log units) above what was measured; the measured number falls inside the stated range.
By their numbers in this assay, from the lowest: compound 2; then compounds 4, 3 and 1 (each within the scatter of the next, the first and the last beyond it).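

In this assay, the step of a 1.7-fold lower number from compound 3 to compound 4 (0.23 log units; within the scatter) shows that this carbonyl carbon can carry 2-(2-hydroxyethyl)piperidin-1-yl in place of the open-chain (3-(methanesulfonamido)propyl)amino without a readable change, although the sulfur leaves with that chain. Among these compounds, the step of a 2.8-fold lower number from compound 1 to compound 4 (0.44 log units; beyond the scatter) is the first to separate two piperidin-1-yl amides at this position, so what the piperidine ring carries matters here, yet the step of a 4.7-fold higher number from compound 2 to compound 4 (0.67 log units; beyond the scatter) leaves compound 2, with its (2,2,6,6-tetramethylpiperidin-4-yl)oxy group, the strongest of the four. No measurement at hand explains why these groups differ.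

The compounds shown leave open whether the low number of compound 2 belongs to its ester link or to its tetramethylpiperidine ring, which an amide carrying the same ring would separate, and whether an unsubstituted piperidin-1-yl amide would sit nearer compound 1 or compound 4. They also leave open what a carboxylic acid, or a chain longer than the 2-hydroxyethyl on the piperidine, would do at this carbonyl carbon.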